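The source may report more compounds than this note shows. Statements on the series, on what has been measured and on what is new or still open speak of the compounds shown alone.

Measured in a physicochemical assay for solubility, read by HPLC, in phosphate buffer, measured as kinetic solubility, at pH 7.4; on this read-out lower numbers stand for lower solubility and higher numbers for higher solubility:
- Compound 1 `CCC(=O)c1cc(-c2ccc(S(N)(=O)=O)cc2)n(-c2ccc(Cl)cc2)n1`: 41900 nM
- Compound 2 `CCC(=O)c1cc(-c2ccc(S(N)(=O)=O)cc2)n(-c2ccc(F)cc2)n1`: 96800 nM
- Compound 3 `CCC(=O)c1cc(-c2ccc(S(N)(=O)=O)cc2)n(-c2cccc(Cl)c2)n1`: 6900 nM

Compound 3 has the lowest number of the three. Compound 4 `CCC(=O)c1cc(-c2ccc(S(N)(=O)=O)cc2)n(-c2ccccc2Cl)n1` differs from it as follows: 2-chlorophenyl in place of 3-chlorophenyl on an aromatic nitrogen. In words, it carries 2-chlorophenyl in place of 3-chlorophenyl on an aromatic nitrogen. The nearest measured precedent is a 6.1-fold lower number from compound 1 to compound 3 (0.78 log units; beyond the scatter), a modest step that also exchanges one chlorophenyl for another. The other step ending at this compound, a 14-fold lower number from compound 2 to compound 3 (1.15 log units; beyond the scatter), is large but also exchanges the halogen. Neither step includes 2-chlorophenyl, so the direction remains uncertain. With compound 3 at 6900 nM, the lowest of the three, a modest rise is expected in this assay. The expected change is a 2.6-fold higher number from compound 3 to compound 4 (0.42 log units; beyond the scatter). Compound 4 is estimated at 18000 nM, with an expected range from 5000 nM to 60000 nM.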

Compound 4, solubility: 4700 nM
Beside the measured number, compound 4's estimate is 3.8-fold (0.58 log units) above it, outside the stated range (below it).
By their numbers in this assay, from the lowest: compounds 4 and 3 (each within the scatter of the next); then compound 1; then compound 2.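

In this assay, 2-chlorophenyl in place of 3-chlorophenyl on the aromatic nitrogen gives a 1.5-fold lower number from compound 3 to compound 4 (0.17 log units; within the scatter), so the two compounds cannot be told apart. The same group gives an 8.9-fold lower number from compound 1 to compound 4 (0.95 log units; beyond the scatter) and, with the halogen also exchanged, a 21-fold lower number from compound 2 to compound 4 (1.31 log units; beyond the scatter), leaving 4-chlorophenyl as the only one of the three chlorophenyl groups that stands apart. No measurement is available that explains this. Going by these compounds, it remains open whether 2-fluorophenyl or 3-fluorophenyl would follow the chlorophenyl pattern, and how a 2-methoxyphenyl or a phenyl bearing an amine would read here.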